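This account rests on a few compounds, and the source may have more. Where it says the series, first, only, none or still open, it means among the compounds named here.

Measured so far:
- compound 1 `CCCS(=O)(=O)Nc1cccc2c1CCC2c1ncc[nH]1` gives 1340 nM in a functional assay on CHO cells for agonist activity at Alpha-1A adrenergic receptor (Homo sapiens), read by FLIPR and calcium flux; a higher number here means that more compound is needed for the effect, a lower number that less compound is needed
- compound 2 `Cn1nccc1-c1cccc2c1CCC2c1ncc[nH]1` gives 278 nM in this assay
- compound 3 `c1ccc2c(c1)CCC2c1ncc[nH]1` gives 473 nM in this assay

Compound 1 stands at the highest of the three numbers, so it needs the most compound for the effect. Compound 4 `c1cc(-c2cn[nH]c2)c2c(c1)C(c1ncc[nH]1)CC2` differs from it in one place: 1H-pyrazol-4-yl in place of (propylsulfonyl)amino on an aromatic carbon. Among the measured compounds shown here, two measured steps bear on this. Replacing the same (propylsulfonyl)amino group gave a 4.8-fold lower number from compound 1 to compound 2 (0.68 log units; beyond the scatter) and a 2.8-fold lower number from compound 1 to compound 3 (0.45 log units; beyond the scatter), both modest drops. A 1H-pyrazol-4-yl, a small aromatic ring with two hetero atoms, resembles the 1-methyl-1H-pyrazol-5-yl of compound 2, so a drop of similar size is expected, and compound 4 is estimated at 300 nM (range 120 nM to 750 nM), which is an expected step of a 4.5-fold lower number from compound 1 to compound 4 (0.65 log units; beyond the scatter).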

Compound 4, half-maximal effective concentration: 14 nM
Estimate against measurement, compound 4: 21-fold (1.33 log units) above; measured number outside the range, below it.
By their numbers in this assay, from the lowest: compound 4; then compounds 2 and 3 (each within the scatter of the next); then compound 1.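

At this aromatic carbon, the earlier replacements moved the number only modestly, but 1H-pyrazol-4-yl gives a far larger change (a 96-fold lower number from compound 1 to compound 4 (1.98 log units; beyond the scatter)) and also beats plain hydrogen (a 34-fold lower number from compound 3 to compound 4 (1.53 log units; beyond the scatter)), so this position can respond strongly to the group placed on it. Two similar-looking pyrazole rings are clearly not interchangeable here (a 20-fold lower number from compound 2 to compound 4 (1.30 log units; beyond the scatter)). Nothing available explains this gain.

Going by these compounds, compound 2 differs from compound 4 in both its methyl group and its ring attachment, so which of these matters remains open. On these data alone, how 1-methyl-1H-pyrazol-4-yl, a phenyl ring or an amine would behave at this carbon also remains open.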